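A few compounds are considered here, and "the series" means these few. Any claim that something is new, unique, unknown or untested is made for them only; others in the source may bear on it.

Of the compounds shown here, three of a shared core have been tested in an ADME assay on NHDF cells (Homo sapiens) for cytotoxicity, read by MTT assay, with a stated time of 72 h; on this read-out lower numbers stand for stronger inhibition and higher numbers for weaker inhibition. Compound 1 `COc1cccc(/C=C2\CCC/C(=C\c3cc(OC)c(OC)c(OC)c3)C2=O)c1OC` gives 7900 nM, compound 2 `COc1cccc(/C=C2\CCC/C(=C\c3ccc(O)c(O)c3)C2=O)c1OC` gives 17900 nM, and compound 3 `COc1ccc(/C=C2\CCC/C(=C\c3ccc(Br)cc3)C2=O)cc1OC` gives 13100 nM. In this assay the number of compound 3 sits close to both others: it lies within the scatter of compound 2 and within the scatter of compound 1, so the three cannot be told apart.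

Compound 4 `COc1ccc(/C=C2\CCC/C(=C\c3cc(Cl)cc(Cl)c3)C2=O)cc1OC` is not yet measured. It differs from compound 3 by 3,5-dichlorophenyl in place of 4-bromophenyl on a double-bonded chain carbon bound to a double-bonded ring carbon. Among the compounds with values here, no measured pair shows the effect of such a change here, so the step from compound 3 to compound 4 is expected to stay within the scatter, in no clear direction, as a 1.1-fold lower number from compound 3 to compound 4 (0.04 log units; within the scatter). Compound 4 is therefore estimated at 12000 nM, from 5500 nM to 26000 nM.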

Compound 4, half-maximal inhibitory concentration: 8300 nM
Estimate against measurement, compound 4: 1.4-fold (0.16 log units) above, and the stated range covers the measured number.
By their numbers in this assay, from the lowest: compounds 1, 4, 3 and 2 (each within the scatter of the next, the first and the last beyond it).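

Within the data shown here, this is the first measured pair for a change on a double-bonded chain carbon bound to a double-bonded ring carbon. In this assay, 3,5-dichlorophenyl in place of 4-bromophenyl gives a 1.6-fold lower number from compound 3 to compound 4 (0.20 log units; within the scatter), so at this position the two halogen-bearing phenyl groups cannot be told apart. No available data bear on this result. From the compounds shown here alone, it remains open whether a phenyl carrying an amine or a carboxylic acid in this place would give a number beyond the scatter of compound 3.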